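Exchanging One Pyrimidinyl Group on a Chemokine Receptor Ligand

The compounds below may be only part of what the source reports. "The series", "measured", "known", "first", "only" and "open" are said of these compounds alone.

Of the compounds shown here, three have been measured in an assay on MDA-MB-231 cells for displacement of a labelled ligand from C-X-C chemokine receptor type 4 (Homo sapiens); a higher number here means that more compound is needed for the effect, a lower number that less compound is needed. Compound 1, `c1ccc(NCc2ccc(CNc3ncccn3)cc2)cc1`, gives 10 nM in this assay. Compound 2, `CSc1ccnc(NCc2ccc(CNc3ncc(F)cn3)cc2)n1`, gives 1 nM, and compound 3, `Fc1cccc(NCc2ccc(CNc3cccc(F)n3)cc2)n1`, gives 100 nM. Compound 2 therefore stands lowest of the three: the gap to compound 1 lies beyond the usual scatter, and the gap to compound 3 is larger still. None of the three pairs differs in only one place, so the numbers show order but not the weight of any single change.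

Compound 4, `Fc1cnc(NCc2ccc(CNc3ncc(F)cn3)cc2)nc1`, does differ from compound 2 in one place: 5-fluoropyrimidin-2-yl in place of 4-(methylsulfanyl)pyrimidin-2-yl on an amine nitrogen. The molecule thus carries the same 5-fluoropyrimidin-2-yl group on both amine nitrogens.

Among the compounds with values here, with no single-point step among the measured compounds to lean on, the direction of the change is open. Compound 1, which carries neither the methylsulfanyl group nor the fluorine, gives 10 nM, while compound 2 gives 1 nM; compound 4 sits structurally between those two cases. Compound 4 is therefore expected to give about 3 nM in this assay, within a range of 1 nM to 10 nM. The expected step of a 3.0-fold higher number from compound 2 to compound 4 (0.48 log units; beyond the scatter) is a modest rise, at the edge of the scatter.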

Compound 4, effective concentration (reported as EC, without a stated level of effect): 1 nM
Estimate against measurement, compound 4: 3.0-fold (0.48 log units) above; the range from low to high includes it.
By their numbers in this assay, from the lowest: compounds 2 and 4 (each within the scatter of the next); then compound 1; then compound 3.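

In this assay, within the data shown here, the exchange at this amine nitrogen gives no change at the digits printed from compound 2 to compound 4 (within the scatter), the first step that can be read at a single place. It shows that, with the rest of the molecule held constant, 4-(methylsulfanyl)pyrimidin-2-yl can give way to 5-fluoropyrimidin-2-yl without a change beyond the scatter, so the sulfur-bearing group is not needed here to keep the number this low. No measurement shown here offers an explanation for this outcome.

This single step replaces one substituted ring with another, so it cannot separate the loss of the methylsulfanyl group from the gain of the fluorine, and it leaves open whether either substituent matters on its own at this nitrogen. Also open, on these data alone, is how far this tolerance extends, for instance to a methoxy group, an amine or a longer chain on the pyrimidine ring, and whether the 5-fluoropyrimidin-2-yl group on the other amine nitrogen would allow the same freedom.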